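Swapping the ester group on a long-chain fumaramide inhibitor

The source may report more compounds than this note shows. Statements on the series, on what has been measured and on what is new or still open speak of the compounds shown alone.

Of the compounds shown here, two have been measured so far. In an assay on HEK293T cells for inhibition of palmitoyltransferase ZDHHC2 (Homo sapiens), read by fluorescence polarization, with stated times of 30 min, 1 min and 2 h, in the presence of a further agent that is not named here (on this read-out lower numbers stand for stronger inhibition and higher numbers for weaker inhibition), compound 1 `C=CC(=O)NCCCCCCCCCCCCCC` gives 59900 nM, whereas compound 2 `CCCCCCCCCCCCCCNC(=O)/C=C\C(=O)OCC#N` gives 2660 nM. Among the compounds with values here, that makes compound 2 the lower of the two numbers, and the only step known is a 23-fold lower number from compound 1 to compound 2 (1.35 log units; beyond the scatter), brought about by 2-(cyanomethoxycarbonyl)ethenyl in place of vinyl on a carbonyl carbon.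

Compound 3 `CCCCCCCCCCCCCCNC(=O)/C=C\C(=O)Oc1ccccc1` has not been measured. It differs from compound 2 by phenyl in place of cyanomethyl on an oxygen next to a carbonyl group. Within the data shown here, no measured step touches this ester position: the one step known changed the group on the carbonyl carbon, and both compound 2 and compound 3 keep that group unchanged. There is thus no direct guide, and the expectation is a change in this assay of no more than the usual scatter in either direction. The expected step is a 1.1-fold higher number from compound 2 to compound 3 (0.05 log units; within the scatter). Compound 3 is therefore estimated at 3000 nM, with a range from 1000 nM to 10000 nM.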

Compound 3, half-maximal inhibitory concentration: 2020 nM
For compound 3 the middle estimate is 1.5-fold (0.17 log units) above the measured one; the measured number falls inside the stated range.
By their numbers in this assay, from the lowest: compounds 3 and 2 (each within the scatter of the next); then compound 1.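

The ester position takes a large swap without a clear shift in this assay: the change is a 1.3-fold lower number from compound 2 to compound 3 (0.12 log units; within the scatter), so compound 2 and compound 3 cannot be told apart, even though an open group with a nitrile and one hydrogen-bond acceptor gives way to a six-membered aromatic ring of carbon only with no such acceptor. The earlier step, a 23-fold lower number from compound 1 to compound 2 (1.35 log units; beyond the scatter), showed what replacing the vinyl group can do, while this pair adds that the nitrile of the cyanomethyl group is not required for a number in this range, and that the group on this oxygen can be either open-chain or aromatic. No measurement here offers an explanation for how closely the two esters agree.

As far as these compounds go, whether the same holds for a simple methyl or ethyl ester, for a phenyl ring carrying a fluorine or a methoxy group, or for a free carboxylic acid at this position remains open. The pair also leaves unsettled whether this insensitivity to the ester group would persist with a shorter or longer chain on the amide nitrogen.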